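Amino to methoxymethyl on the amide side chain

This account rests on a few compounds, and the source may have more. Where it says the series, first, only, none or still open, it means among the compounds named here.

- compound 1 `CC(=O)N1CCc2c(C)c3c(n2-c2ccc(C(N)=O)c(c2)N[C@@H](C)[C@H](C)C1)CC(C)(C)CC3=O`: 15 nM
- compound 2 `Cc1c2c(n3c1CCN(C(=O)CN)C[C@@H](C)[C@H](C)Nc1cc-3ccc1C(N)=O)CC(C)(C)CC2=O`: 190 nM

Among the measured compounds shown here, in a functional assay on NCI-H1975 cells (Homo sapiens) for antiproliferative activity (a higher number here means a weaker inhibitor, a lower number a stronger inhibitor), compound 2 gives 190 nM, the higher of the two numbers so far. Compound 3 `COCCC(=O)N1CCc2c(C)c3c(n2-c2ccc(C(N)=O)c(c2)N[C@@H](C)[C@H](C)C1)CC(C)(C)CC3=O` is the next to be read. It carries methoxymethyl in place of the amino of compound 2, on a saturated chain carbon bound to a carbonyl carbon: methoxymethyl in place of amino on a saturated chain carbon bound to a carbonyl carbon.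

For the measured compounds named here, only one measured step bears on this change: a 13-fold higher number from compound 1 to compound 2 (1.10 log units; beyond the scatter). This large step came with amino in place of hydrogen in that same place. Compound 3 has no amino there, so a return toward the number of compound 1, 15 nM, is the expectation. Going by the values given here, the return may be incomplete, since no measured compound carries methoxymethyl and its comparison with hydrogen is unknown. The expected move in this assay is a clear one toward a lower number, beyond the scatter: a 5.4-fold lower number from compound 2 to compound 3 (0.73 log units; beyond the scatter). The estimate for compound 3 is 35 nM, with an expected range of 12 nM to 110 nM.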

Compound 3, half-maximal inhibitory concentration: 31 nM
Beside the measured number, compound 3's estimate is 1.1-fold (0.05 log units) above it; measured number inside the range.
By their numbers in this assay, from the lowest: compound 1; then compound 3; then compound 2.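

Replacing amino with methoxymethyl on this saturated chain carbon bound to a carbonyl carbon recovers most of the ground lost in this assay (a 6.1-fold lower number from compound 2 to compound 3 (0.79 log units; beyond the scatter)). A substituent on this carbon therefore need not carry the large penalty seen with amino: methoxymethyl in place of hydrogen gives a smaller step (a 2.1-fold higher number from compound 1 to compound 3 (0.32 log units; beyond the scatter)) than amino in place of hydrogen (a 13-fold higher number from compound 1 to compound 2 (1.10 log units; beyond the scatter)). Compound 1, with hydrogen, still has the lowest number of the three, and both substituted compounds stand above it beyond the scatter, so neither group improves on hydrogen at this position.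

Amino and methoxymethyl differ in both heavy atoms and hydrogen-bond donors, so these compounds cannot show which difference goes with the change in number; a hydroxymethyl group, a dimethylamino group or a longer ether chain on the same carbon would begin to separate the two. No measurement at hand accounts for the gap between amino and methoxymethyl.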